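Replacing 3,4-difluorophenyl with 3-chlorophenyl on the shared core

A few compounds are considered here, and "the series" means these few. Any claim that something is new, unique, unknown or untested is made for them only; others in the source may bear on it.

- compound 1 `CC(C)c1ccc(Nc2ccc3c(OCCCN4CCN(C)CC4)cccc3n2)cc1`: 13200 nM
- compound 2 `CN1CCN(CCCOc2cccc3nc(Nc4ccc(F)c(F)c4)ccc23)CC1`: 4160 nM
- compound 3 `CN1CCN(CCCOc2cccc3nc(Nc4cccc(Cl)c4)ccc23)CC1`: not yet measured

Among the compounds with values here, in a functional assay on cells (Panel renal (Carcinoma cell lines), Homo sapiens) for inhibition, read by sulforhodamine B assay, with a stated time of 48 h (on this read-out lower numbers stand for stronger inhibition of growth and higher numbers for weaker inhibition of growth), compound 2 has the lower of the two numbers so far. The move to compound 3 is 3-chlorophenyl in place of 3,4-difluorophenyl on a nitrogen on an aromatic ring. Within the data shown here, only one measured step bears on this, a modest one at the same place: a 3.2-fold lower number from compound 1 to compound 2 (0.50 log units; beyond the scatter). That step replaced 4-isopropylphenyl, while this change swaps one substituted phenyl for another. A small rise that stays within the scatter is therefore expected, with an estimated 1.2-fold higher number from compound 2 to compound 3 (0.08 log units; within the scatter). The expected value for compound 3 is 5000 nM, within an estimated range of 2200 nM to 11000 nM.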

Compound 3, concentration for 50% growth inhibition: 1900 nM
The estimate for compound 3 lay 2.6-fold (0.42 log units) above the measured number; the whole stated range lies above it.
By their numbers in this assay, from the lowest: compound 3; then compound 2; then compound 1.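

In this assay the group on this nitrogen still matters when one substituted phenyl replaces another: the data show a 2.2-fold lower number from compound 2 to compound 3 (0.34 log units; beyond the scatter) and so more than the effect of leaving 4-isopropylphenyl. The wider comparison gives a 6.9-fold lower number from compound 1 to compound 3 (0.84 log units; beyond the scatter) and places 3-chlorophenyl lowest of the three, beyond the scatter from both others. Nothing measured here explains this difference. Open, going by these compounds, is whether 3,4-dichlorophenyl or 3-bromophenyl would lower the number further, and whether a pyridine ring could take the place of the phenyl ring.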